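Swapping Benzyl for Tert-Butyl on a Weak Inhibitor Pair

A few compounds are considered here, and "the series" means these few. Any claim that something is new, unique, unknown or untested is made for them only; others in the source may bear on it.

Compound 1 `[O-]/[N+](=C\c1cn(-c2ccc(C(F)(F)F)cc2)nn1)Cc1ccccc1` and compound 2 `CCCCCCCCn1cc(/C=[N+](\[O-])Cc2ccccc2)nn1` carry the same side arm but differ in their cores; the difference between the two cores is not broken down here. In a functional assay on THP-1 cells (Homo sapiens) for inhibition, read by ELISA, with stated times of 2 h and 48 h (a lower number here means a stronger inhibitor, a higher number a weaker inhibitor), compound 1 gives 15400 nM, and compound 2 gives 13100 nM. Compound 3 `CC(C)(C)/[N+]([O-])=C/c1cn(-c2ccc(C(F)(F)F)cc2)nn1` differs from compound 1 by tert-butyl in place of benzyl on a double-bonded nitrogen, and in this assay compound 3 gives 14400 nM, so that the step is a 1.1-fold lower number from compound 1 to compound 3 (0.03 log units; within the scatter). Compound 4 `CCCCCCCCn1cc(/C=[N+](\[O-])C(C)(C)C)nn1` arises from compound 2 by the same change, (tert-butyl in place of benzyl on a double-bonded nitrogen). Because the measured step of a 1.1-fold lower number from compound 1 to compound 3 (0.03 log units; within the scatter) stayed within the scatter, the expected step in this assay is a 1.0-fold lower number from compound 2 to compound 4 (0.02 log units; within the scatter). On that basis compound 4 is estimated at 12500 nM, most likely falling between 6000 nM and 26000 nM.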

Compound 4, half-maximal inhibitory concentration: 7900 nM
For compound 4 the middle estimate is 1.6-fold (0.20 log units) above the measured one; the range from low to high includes it.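

In this assay, the new step is a 1.7-fold lower number from compound 2 to compound 4 (0.22 log units; within the scatter). Set beside the earlier step, it shows that the swap of benzyl for tert-butyl on a double-bonded nitrogen gives steps on these two cores that cannot be told apart: the same change on two cores in this assay, a 1.1-fold lower number (0.03 log units; within the scatter) from compound 1 to compound 3 and a 1.7-fold lower number (0.22 log units; within the scatter) from compound 2 to compound 4, 1.6-fold (0.19 log units) apart, within the scatter of two such steps. Within the data shown here, with only two pairs, and each step within the scatter, this does not show that the swap strengthens inhibition, nor that it would behave the same way on any other core.

Going by these compounds, it remains open whether a different group on that nitrogen, such as a cyclohexyl ring or a longer chain, would move the number beyond the scatter. On these data alone, the effect of adding an amine or a carboxylic acid also remains open.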